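Methyl for nitro on a weakly active flavone core

A few compounds are considered here, and "the series" means these few. Any claim that something is new, unique, unknown or untested is made for them only; others in the source may bear on it.

Compound 1 `O=c1cc(-c2ccccc2)oc2ccc(N3COc4c(cccc4[N+](=O)[O-])C3)cc12` is tested in a functional assay on MCF7 cells (Homo sapiens) for inhibition, read by MTT assay, with a stated time of 48 h, tested at 7.5 ug/mL (a lower number here means less inhibition of growth, a higher number more inhibition of growth at the concentration tested), where compound 1 gives 8.2%. Among the compounds with a number, this is the highest, but compound 2 `O=c1cc(-c2ccccc2)oc2cc(N3COc4c(Br)cccc4C3)ccc12` gives 2.21%, which lies within the usual scatter of compound 1, so the two cannot be told apart. Compound 3 `O=c1cc(-c2ccccc2)oc2cc(N3COc4c(Cl)cc(Cl)cc4C3)ccc12` is reported only as "not active" (no number reported), without a number. Compound 4 `Cc1cccc2c1OCN(c1ccc3oc(-c4ccccc4)cc(=O)c3c1)C2` has not been measured; it differs from compound 1 by methyl in place of nitro on an aromatic carbon. For the measured compounds named here, no measured pair shows this change, so the step of a number 3.2 percentage points lower from compound 1 to compound 4 (within the scatter) is expected to stay within the scatter, in no particular direction. Compound 4 is estimated at 5%, ranging from 0% to 15%.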

Compound 4, percent growth inhibition at one concentration: 30.4%
The estimate for compound 4 lay 25.4 percentage points below the measured number; measured number above the stated range.
By their numbers in this assay, from the lowest: compounds 2 and 1 (each within the scatter of the next); then compound 4.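

In this assay, for the compounds shown here, methyl in place of nitro on this aromatic carbon gives a number 22.2 percentage points higher from compound 1 to compound 4 (beyond the scatter), the first comparison here of two compounds that differ in one place. It shows that the group on this carbon can move growth inhibition beyond the usual scatter while the rest of the molecule stays the same. Nothing available here accounts for this step. With only nitro and methyl compared at this carbon, one pair sets no trend. From the compounds shown here alone, whether an amine, a methoxy group or a longer chain here would raise or lower growth inhibition remains open.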